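Compound 3 to compound 4: chloro on the phenyl

This account rests on a few compounds, and the source may have more. Where it says the series, first, only, none or still open, it means among the compounds named here.

In a functional assay on A-375 cells (Homo sapiens) for cytotoxicity, read by CCK-8 assay, with a stated time of 24 h (on this read-out higher numbers stand for weaker inhibition and lower numbers for stronger inhibition), compound 3 `COc1ccccc1Oc1c(N)nc(-c2ccccc2)nc1OCCO` gives > 80000 nM, which is a limit of the assay and not a number. Its true position is therefore unknown, and any step from it starts from that limit.

Compound 4 `COc1ccccc1Oc1c(N)nc(-c2cccc(Cl)c2)nc1OCCO` keeps the 2-hydroxyethoxy group and differs from compound 3 by chloro in place of hydrogen on an aromatic carbon, phenyl to 3-chlorophenyl (chloro in place of hydrogen on an aromatic carbon). The new chloro sits meta to a large group.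

For the measured compounds named here, two measured steps bear on this change. Compound 1 `COc1ccccc1Oc1c(N)nc(-c2ccccc2)nc1Cl` gives 7220 nM and compound 2 `COc1ccccc1Oc1c(N)nc(-c2ccc(Br)cc2)nc1Cl` gives 63 nM. Bromo in place of hydrogen accounts for a 110-fold lower number from compound 1 to compound 2 (2.06 log units; beyond the scatter), a large step. That step involves bromo rather than chloro, and it was measured with chloro rather than 2-hydroxyethoxy on the shared core, so only part of it is expected to carry over. The second step, 2-hydroxyethoxy in place of chloro, is an at least 11-fold higher number from compound 1 to compound 3 (1.04 log units; beyond the scatter), also large, and compound 4 retains that group.

A lower number is expected, though probably by less than the bromo step, and a reading at the limit remains possible. The expected change is an at least 6.6-fold lower number from compound 3 to compound 4 (0.82 log units; beyond the scatter). For compound 4 the estimate is 12000 nM, with an expected range of 1500 nM to 80000 nM.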

Compound 4, half-maximal inhibitory concentration: 30200 nM
Estimate against measurement, compound 4: 2.5-fold (0.40 log units) below; the range from low to high includes it.
By their numbers in this assay, from the lowest: compound 2; then compound 1; then compound 4. At a limit, above all of these: compound 3.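

The change from phenyl to 3-chlorophenyl, with the new chloro meta to a large group, moves the 2-hydroxyethoxy compounds off the limit in this assay (an at least 2.6-fold lower number from compound 3 to compound 4 (0.42 log units; beyond the scatter)), so a substituent at this position changes the number with the 2-hydroxyethoxy group kept. The earlier step, a 110-fold lower number from compound 1 to compound 2 (2.06 log units; beyond the scatter), was measured with bromo and with chloro on the shared core, so it could not show this. Compound 3 gives > 80000 nM which is a limit of the assay and not a number, and the true size of the step stays unknown because of where that compound sits: the limit of > 80000 nM in this assay, at which 1 of the 4 values shown sits.

The compounds shown leave open whether this chloro would give a step of similar size with chloro instead of 2-hydroxyethoxy on the shared core, and whether bromo would go further than chloro on the phenyl of compound 3. Also open, from the compounds shown here alone, is how a group such as an amine or a carboxylic acid, or a longer chain, would read in this assay in place of 2-hydroxyethoxy alongside the 3-chlorophenyl of compound 4.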